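Chloro in place of methoxy, compound 2 to compound 3

The source may report more compounds than this note shows. Statements on the series, on what has been measured and on what is new or still open speak of the compounds shown alone.

Values measured in an ADME assay on J774 cells (Mus musculus) for cytotoxicity (on this read-out higher numbers stand for an effect only at larger amounts of compound and lower numbers for an effect already at smaller amounts), are as follows.

Compound 1 `Cc1[nH]c2ccccc2c(=O)c1Cc1ccccc1` gives > 40100 nM as a limit.
Compound 2 `COc1ccc2c(=O)c(Cc3ccccc3)c(C)[nH]c2c1` gives > 35800 nM as a limit.

Compound 2 has no number in this assay and stands only at the limit > 35800 nM of the assay. Compound 1 is likewise known only by a limit.

Compound 3 `Cc1[nH]c2cc(Cl)ccc2c(=O)c1Cc1ccccc1` differs from compound 2 in one place chloro in place of methoxy on an aromatic carbon with chloro in place of methoxy on an aromatic carbon of a six-membered aromatic ring of carbon only. Among the measured compounds shown here, the one measured step that bears on this change is the methoxy step (a step that the two limits leave unreadable from compound 1 to compound 2) and its size cannot be read. For the measured compounds named here, no chloro compound has been measured yet. Resting on the limit of compound 2 (> 35800 nM) no step beyond the scatter is expected in this assay and a further limit is the likeliest report. Expressed as a step, a step that the limit leaves unreadable from compound 2 to compound 3 is expected. The estimated value for compound 3 is 36000 nM with an expected range from 15000 nM to 60000 nM on this read-out.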

Compound 3, half-maximal effective concentration in the J774 assay: > 35200 nM
Compound 3: no number, only a limit; the forecaster's own chance of this, stated with the estimate: 80%; the middle value lies beyond the limit too.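

In the J774 assay compound 1 gives > 40100 nM as a limit. In the J774 assay compound 2 gives > 35800 nM as a limit. In the J774 assay compound 3 gives > 35200 nM as a limit. In the J774 assay no step can be read among compound 1, compound 2 and compound 3, as each of the three is known only by a limit. The compounds shown leave open where the half-maximal effect of each lies, and whether hydrogen, methoxy and chloro on this aromatic carbon differ at all on this read-out. In a physicochemical assay for lipophilicity, at pH 7.4 (on this read-out lower numbers stand for lower lipophilicity and higher numbers for higher lipophilicity), compound 2 gives 2.52 and compound 3 gives 2.69 on this read-out. In the physicochemical assay that is a number 0.17 log units higher from compound 2 to compound 3 (within the scatter) for chloro in place of methoxy on an aromatic carbon.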